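Swapping one fused ring group on the compound 2 scaffold

This account rests on a few compounds, and the source may have more. Where it says the series, first, only, none or still open, it means among the compounds named here.

Compound 1 `COc1ccc2nccc(CC[C@H]3OC[C@H](NCc4ccc(Cl)c(Cl)c4)CO3)c2c1` gives 20000 nM
Compound 2 `COc1ccc2nccc(CC[C@H]3OC[C@H](NCc4ccc5c(c4)OCCO5)CO3)c2c1` gives 7400 nM
Compound 3 `COc1ccc2nccc(CC[C@H]3CC[C@H](NCc4cc5c(cn4)OCCO5)CC3)c2c1` gives 7500 nM

All three numbers come from an ADME assay on K562 cells (Homo sapiens) for antiproliferative activity (a higher number here means a weaker inhibitor, a lower number a stronger inhibitor), and they span a narrow range. Compound 2 and compound 3 share the low end, within the scatter of each other, while compound 1 sits clearly higher.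

The next compound to be measured is compound 4 `COc1ccc2nccc(CC[C@H]3OC[C@H](NCc4cc5c(cn4)OCCC5)CO3)c2c1` which keeps everything in compound 2 except one group, on a saturated chain carbon bound to an amine nitrogen. The change is this: a group of 10 heavy atoms (8 carbon, 1 nitrogen, 1 oxygen; one six-membered non-aromatic ring with 1 hetero atom, one six-membered aromatic ring with 1 hetero atom) in place of a group of 10 heavy atoms (8 carbon, 2 oxygen; one six-membered non-aromatic ring with 2 hetero atoms, one six-membered aromatic ring of carbon only), on a saturated chain carbon bound to an amine nitrogen and the two groups match in size.

Going by the values given here, only one measured step touches this place. That step, a 2.7-fold lower number from compound 1 to compound 2 (0.43 log units; beyond the scatter), brought in 2,3-dihydro-1,4-benzodioxin-6-yl in place of 3,4-dichlorophenyl, and it was modest. Among the compounds with values here, it replaced a quite different group, whereas compound 4 swaps two closely matched ones, and no measured step tests this swap directly. A small effect is therefore expected in this assay with nothing beyond the scatter and no firm direction. The expected change is a 1.1-fold higher number from compound 2 to compound 4 (0.03 log units; within the scatter) as an estimate only. The estimated value for compound 4 is 8000 nM with an expected range (from 3000 nM to 20000 nM).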

Compound 4, half-maximal inhibitory concentration: 32000 nM
Compound 4: middle estimate off by 4.0-fold (0.60 log units), on the low side; measured number outside the range, above it.
By their numbers in this assay, from the lowest: compounds 2 and 3 (each within the scatter of the next); then compounds 1 and 4 (each within the scatter of the next).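

At this place, on a saturated chain carbon bound to an amine nitrogen, two groups with matching heavy-atom and hydrogen-bond counts still read differently in this assay, with a 4.3-fold higher number from compound 2 to compound 4 (0.64 log units; beyond the scatter) as the step. Matching those counts is therefore not enough to preserve the result here, and the 2,3-dihydro-1,4-benzodioxin-6-yl group cannot be exchanged freely for this similar two-ring group. The new group also gives up the separation from 3,4-dichlorophenyl, since a 1.6-fold higher number from compound 1 to compound 4 (0.20 log units; within the scatter) leaves those two compounds within the scatter of each other. Nothing available here explains the loss.

The swap makes two changes at once, placing a nitrogen in the aromatic ring and leaving only one oxygen in the non-aromatic ring, so the compounds shown do not reveal which change accounts for the step. From the compounds shown here alone, on the same core, chroman-6-yl, with its carbon-only aromatic ring and single ring oxygen, would separate the two changes, while the answer in other assays and with other cores remains open.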